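A few compounds are considered here, and "the series" means these few. Any claim that something is new, unique, unknown or untested is made for them only; others in the source may bear on it.

Measured so far:
Compound 1, `CCCCNC(=O)OCC(O)Cn1cc(CN(C)CCC(C)C)nn1`: in an assay on nucleic acid for inhibition of Nucleic Acid, read by fluorescence, tested at 100 uM (a higher number here means more inhibition at the concentration tested (going by the name of the read-out), a lower number less inhibition), compound 1 gives 24%.
Compound 2, `CCCCN(CCCC)Cc1cn(CC(O)COC(=O)C2CCCCC2)nn1`: in this assay compound 2 gives 12%.

Compound 2 stands lowest of the two numbers shown; its nearest neighbour is compound 1, whose reading is higher by a margin beyond the usual scatter. Within the data shown here, the two differ in more than one place, so no single step between them is drawn.

Compound 3, `CC(C)CCN(C)Cc1cn(CC(O)COC(=O)C2CCCCC2)nn1`, is the next compound to be measured in this assay. It keeps the ester side of compound 2 and alters the amine: isopentyl(methyl)amino in place of dibutylamino on a saturated chain carbon bound to an aromatic carbon. Among the measured compounds shown here, the amine that enters is the one carried by compound 1. Since the two measured compounds differ in both the amine and the ester, nothing here separates the share of each part. The expected step from compound 2 to compound 3 of a number 6 percentage points higher from compound 2 to compound 3 (within the scatter) is therefore a modest rise, in the direction of compound 1, and it may well stay within the scatter. Compound 3 is estimated to give 18% in this assay, with a range from 6% to 30%.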

Compound 3, a percentage reported as inhibition, at one concentration (the size of the read-out at that concentration, not a potency): 0%
Estimate against measurement, compound 3: 18 percentage points above; measured number below the stated range.
By their numbers in this assay, from the lowest: compound 3; then compound 2; then compound 1.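

In this assay, isopentyl(methyl)amino in place of dibutylamino on a saturated chain carbon bound to an aromatic carbon gives a number 12 percentage points lower from compound 2 to compound 3 (beyond the scatter) and so shows, with the ester side held fixed, that the reading responds to the amine alone. Compound 1 and compound 2 differ in two places and could not show this. With the amine held fixed, cyclohexyl in place of butylamino on a carbonyl carbon gives a number 24 percentage points lower from compound 1 to compound 3 (beyond the scatter) as a second single-place change, so the reading responds to that side of the molecule as well, while no measurement shown accounts for either step.

Going by these compounds, what remains open is whether the drop follows the amine as a whole or some particular feature of it, and a ring amine such as piperidine or a small one such as dimethylamino in the same place would bear on that question. On these data alone, it is also open whether the two changes act independently, which the pairing of dibutylamino with butylamino on the carbonyl carbon would test.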